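The source may hold more compounds than are shown below. What is called first, only, known or untested is meant among the compounds shown, and "the series" means these compounds.

Measured so far:
compound 1 `COc1ccc(-c2cc(/C=C/C(=O)c3ccc(N)cc3)[nH]n2)cc1` — 30400 nM
compound 2 `COc1cc(-c2cc(/C=C/C(=O)c3ccc(Cl)c(Cl)c3)[nH]n2)cc(OC)c1OC` — > 100000 nM

Among the compounds with values here, compound 1 stands as the only compound with an actual number in a functional assay on SK-MEL-5 cells (Homo sapiens) for inhibition, read by sulforhodamine B assay, with a stated time of 48 h; a lower number here means that less compound is tolerated, a higher number that more compound is tolerated; here compound 1 gives 30400 nM. Compound 2 reaches only a limit in this assay, recorded as > 100000 nM, which is the limit of > 100000 nM in this assay, at which 1 of the 2 values shown sits. Compound 3 `COc1ccc(-c2cc(/C=C/C(=O)c3ccc(N)cc3)[nH]n2)cc1OC` differs from compound 1 by methoxy in place of hydrogen on an aromatic carbon. Within the data shown here, no measured pair shares this change, so no step beyond the usual scatter is expected in either direction. Compound 3 is therefore estimated at 30000 nM, within 10000 nM to 100000 nM, the expected step being a 1.0-fold lower number from compound 1 to compound 3 (0.01 log units; within the scatter).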

Compound 3, concentration lethal to 50% of the cells: 36100 nM
Beside the measured number, compound 3's estimate is 1.2-fold (0.08 log units) below it; measured number inside the range.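

In this assay, within the data shown here, putting methoxy in place of hydrogen on an aromatic carbon, ortho to a methoxy group and meta to a large group, gives a 1.2-fold higher number from compound 1 to compound 3 (0.07 log units; within the scatter) and is the first step that can be read. This position therefore takes a methoxy group with no change that stands out from the scatter. Nothing measured here bears on why this is so.

As far as these compounds go, whether an amine, a carboxylic acid or a longer chain at the same position would behave alike remains open.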